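Adding a Second Hydroxy Group: Will the Step Repeat?

A few compounds are considered here, and "the series" means these few. Any claim that something is new, unique, unknown or untested is made for them only; others in the source may bear on it.

Compound 1 `O=c1cc(-c2ccc([N+](=O)[O-])cc2)oc2cc(O)ccc12`: > 25 ug/mL
Compound 2 `O=c1cc(-c2ccc([N+](=O)[O-])cc2)oc2c(O)c(O)ccc12`: 4.69 ug/mL
Compound 3 `COc1cc(-c2cc(=O)c3ccc(O)cc3o2)cc(OC)c1O[Si](C)(C)C(C)(C)C`: 4.47 ug/mL

All three were tested in a functional assay on MCF7 cells (Homo sapiens) for cytotoxicity, read by MTT assay, with a stated time of 6 days; a lower number here means that less compound is needed, a higher number that more compound is needed for the effect. For compound 1 the result > 25 ug/mL is a limit of the assay, not a number. Compound 2 gives 4.69 ug/mL and compound 3 gives 4.47 ug/mL; these two lie within the usual scatter of each other. Compound 2 arises from compound 1 by hydroxy in place of hydrogen on an aromatic carbon and this brings an at least 5.3-fold lower number from compound 1 to compound 2 (0.72 log units; beyond the scatter). Because the limit of > 25 ug/mL in this assay, at which 1 of the 3 values shown sits, the size of this step is known only as a lower bound.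

Compound 4, `COc1cc(-c2cc(=O)c3ccc(O)c(O)c3o2)cc(OC)c1O[Si](C)(C)C(C)(C)C`, stands to compound 3 exactly as compound 2 stands to compound 1: hydroxy in place of hydrogen on an aromatic carbon. How the core of compound 1 differs from the core of compound 3 is not broken down here.

The expected step is a 3.0-fold lower number from compound 3 to compound 4 (0.47 log units; beyond the scatter), set a little more cautiously than the measured at least 5.3-fold lower number from compound 1 to compound 2 (0.72 log units; beyond the scatter) because that one rests on the limit (the limit of > 25 ug/mL in this assay, at which 1 of the 3 values shown sits). Compound 4 is therefore expected to give 1.5 ug/mL, most plausibly between 0.5 ug/mL and 5 ug/mL.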

Compound 4, concentration for half-maximal effect: 0.31 ug/mL
Beside the measured number, compound 4's estimate is 4.8-fold (0.68 log units) above it; measured number outside the range, below it.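

The new step brings a 14-fold lower number from compound 3 to compound 4 (1.16 log units; beyond the scatter), so the hydroxy group that lowered the number on the core of compound 1 does the same on the core of compound 3. Compound 1 gives > 25 ug/mL, which is a limit of the assay and not a number. The two steps therefore point the same way, but this is one change on only two cores, which makes no general rule, and their sizes cannot be ranked: the same change on two cores in this assay, an at least 5.3-fold lower number (0.72 log units; beyond the scatter) from compound 1 to compound 2 and a 14-fold lower number (1.16 log units; beyond the scatter) from compound 3 to compound 4; the limit leaves it open whether they differ

The compounds shown leave open whether another group in the same place, such as an amine or a fluorine atom, would bring a similar step, or whether the hydroxy group is needed. Going by these compounds, it also remains open whether the step would carry over to a third core, for example one with a carboxylic acid in place of the nitro group of compound 2.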